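The source may report more compounds than this note shows. Statements on the series, on what has been measured and on what is new or still open speak of the compounds shown alone.

Measured compounds in the series:

compound 1 `COc1ccc(/C=C\C(=O)O)c(OCc2cn(-c3ccc(NC(=O)c4ccccc4)cc3)nn2)c1CC=C(C)C`, 17200 nM
compound 2 `COc1ccc(/C=C\C(=O)O)c(OCc2cn(-c3ccccc3)nn2)c1CC=C(C)C`, 29200 nM
compound 3 `COc1ccc(-n2cc(COc3c(/C=C\C(=O)O)ccc(OC)c3CC=C(C)C)nn2)cc1`, "not determined" (no result reported)

The only read-out is a functional assay on NCI-H322 cells (Homo sapiens) for cytotoxicity, read by MTT assay, with a stated time of 24 h; on this read-out higher numbers stand for weaker inhibition and lower numbers for stronger inhibition. Compound 1 gives 17200 nM and compound 2 gives 29200 nM; the step of a 1.7-fold higher number from compound 1 to compound 2 (0.23 log units; within the scatter), hydrogen in place of benzamido on an aromatic carbon, lies within the scatter, so these two values cannot be told apart. For compound 3 no number exists in this assay; it stands outside the measured set, and nothing can be said of its own level.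

Compound 4 `COc1ccc(/C=C\C(=O)O)c(OCc2cn(-c3cccc([N+](=O)[O-])c3)nn2)c1CC=C(C)C` differs from compound 3 by 3-nitrophenyl in place of 4-methoxyphenyl on an aromatic nitrogen. Going by the values given here, the one measured step, from compound 1 to compound 2, also alters the group on the aromatic nitrogen of the five-membered aromatic ring with three nitrogens, and it produced no change beyond the scatter. Among the compounds with values here, that step is the only guide for the change from compound 3 to compound 4, and it points to no step beyond the scatter in this assay for exchanges of this kind. Compound 4 is therefore expected to land near the level set by compound 1 and compound 2, estimated at 22000 nM with a range of 8000 nM to 60000 nM.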

Compound 4, half-maximal inhibitory concentration: 43200 nM
The estimate for compound 4 lay 2.0-fold (0.29 log units) below the measured number, and the stated range covers the measured number.
By their numbers in this assay, from the lowest: compounds 1, 2 and 4 (each within the scatter of the next, the first and the last beyond it).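

With 3-nitrophenyl on the aromatic nitrogen, this assay gives a 1.5-fold higher number from compound 2 to compound 4 (0.17 log units; within the scatter), so a nitro group on the phenyl, like the benzamido group before it, leaves the number within the scatter of the unsubstituted phenyl of compound 2. Compound 2 therefore now has two substituted neighbours that cannot be told apart from it, although compound 1 at 17200 nM and compound 4 at 43200 nM lie beyond the scatter of each other; the three numbers form a shallow spread, and no single exchange on the phenyl stands out from compound 2. The step from compound 3 to compound 4 cannot be read, since compound 3 has no number in this assay and the 4-methoxyphenyl group therefore adds nothing to this comparison.

Open, as far as these compounds go, is whether an amine or a carboxylic acid on the phenyl, or a longer alkyl chain in place of the phenyl on the aromatic nitrogen, would move the number beyond the scatter of compound 2. Nothing at hand bears on why the three numbers fall where they do.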